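A few compounds are considered here, and "the series" means these few. Any claim that something is new, unique, unknown or untested is made for them only; others in the source may bear on it.

Of the compounds shown here, three sharing one core have been tested in a functional assay on SK-BR-3 cells (Homo sapiens) for antiproliferative activity, read by MTT assay, with a stated time of 72 h; on this read-out lower numbers stand for stronger inhibition and higher numbers for weaker inhibition. Compound 1 `CCN1CCN(c2cc(C)c3cc(NC(=O)c4cccnc4)ccc3n2)CC1` gives 10600 nM. Compound 2 `Cc1cc(NCCN2CCCC2)nc2ccc(NC(=O)c3ccc(Cl)c(Cl)c3)cc12` gives 9530 nM, and compound 3 `Cc1cc(N2CCCCC2)nc2ccc(NC(=O)c3ccc(Cl)c(Cl)c3)cc12` gives 42500 nM. Among these numbers compound 1 holds the second highest, though its gap to compound 2 lies within the scatter, while compound 3 stands beyond the scatter above it. Among the compounds with values here, the only measured step, a 4.5-fold higher number from compound 2 to compound 3 (0.65 log units; beyond the scatter), concerns a different part of the molecule, so it bears only loosely on the change considered here. Compound 4 `CCN1CCN(c2cc(C)c3cc(NC(=O)c4ccc5ccccc5n4)ccc3n2)CC1` differs from compound 1 in one place: quinolin-2-yl in place of pyridin-3-yl on a carbonyl carbon. Within the data shown here, no measured step touches the group on the carbonyl carbon, so the expectation rests on compound 1 alone and carries a wide range. Compound 4 is expected to give 8000 nM, within 2500 nM to 25000 nM. The step expected is a 1.3-fold lower number from compound 1 to compound 4 (0.12 log units; within the scatter), with no movement beyond the scatter the most likely outcome.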

Compound 4, half-maximal inhibitory concentration: 3760 nM
Compound 4: the middle estimate sits 2.1-fold (0.33 log units) above what was measured; measured number inside the range.
By their numbers in this assay, from the lowest: compound 4; then compounds 2 and 1 (each within the scatter of the next); then compound 3.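

In this assay, quinolin-2-yl in place of pyridin-3-yl on the carbonyl carbon gives a 2.8-fold lower number from compound 1 to compound 4 (0.45 log units; beyond the scatter), a modest step but the first measured one at this position. Within the data shown here, it shows that the group on the carbonyl carbon can move the number beyond the scatter, whereas the only earlier step concerned a different part of the molecule. The entering group adds a six-membered aromatic ring of carbon only and keeps the same counts of hydrogen-bond donors and acceptors, but no measurement shown gives a reason for the step.

Still open, from the compounds shown here alone, is whether the added carbon ring alone accounts for the step, which a naphthalen-2-yl or pyridin-2-yl group on the same carbonyl carbon could help to separate. Also open, going by these compounds, is whether quinolin-2-yl would give a similar step on a core carrying a different amine.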